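A few compounds are considered here, and "the series" means these few. Any claim that something is new, unique, unknown or untested is made for them only; others in the source may bear on it.

Compound 1, `NC(=O)c1c(NC(=O)c2ccccc2Cl)sc2c1CCN(Cc1ccc(Cl)cc1)C2`: in a functional assay on HeLa cells (Homo sapiens) for antiproliferative activity, with a stated time of 24 h (a higher number here means a weaker inhibitor, a lower number a stronger inhibitor), compound 1 gives > 50000 nM, which is a limit of the assay and not a number.
Compound 2, `NC(=O)c1c(NC(=O)c2ccc(C(F)(F)F)cc2)sc2c1CCN(Cc1ccc(Cl)cc1)C2`: in this assay compound 2 gives > 50000 nM, again only a limit.
Compound 3, `NC(=O)c1c(NC(=O)c2ccc(C(F)(F)F)cc2)sc2c1CCN(Cc1ccc(Cl)cc1Cl)C2`: in this assay compound 3 gives > 50000 nM, again only a limit.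

Compound 1 therefore stands nowhere on a scale of numbers; it sits at the limit, and so do the two other values shown, so that the limit of > 50000 nM in this assay, at which 3 of the 3 values shown sit, is all the measured evidence there is. The step that the two limits leave unreadable from compound 1 to compound 2 and the step that the two limits leave unreadable from compound 2 to compound 3 are both unreadable, since both ends sit at the limit.

The unmeasured compound 4, `Cc1ccccc1NC(=S)N1CCc2c(sc(NC(=O)c3ccccc3Cl)c2C(N)=O)C1`, differs from compound 1 in this way: a group of 10 heavy atoms (8 carbon, 1 nitrogen, 1 sulfur; one six-membered aromatic ring of carbon only) in place of a group of 8 heavy atoms (7 carbon, 1 chlorine; one six-membered aromatic ring of carbon only), on an amine nitrogen in a ring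

Neither measured step touches the amine nitrogen in the ring, and neither has a readable size, so there is no measured support for any direction or size of change. With all three shown values at the limit, compound 4 is expected to remain near that limit too, and the step that the limit leaves unreadable from compound 1 to compound 4 is expected to be small or unreadable. Compound 4 is estimated at 60000 nM in this assay, with a range from 15000 nM to 250000 nM.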

Compound 4, half-maximal inhibitory concentration: > 50000 nM
Compound 4 ended at the assay's limit; the forecaster's own chance of this, stated with the estimate: 75%; the middle value does not contradict the limit.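

The change from compound 1 to compound 4 gives no readable step, since both compounds stand only at a limit: the limit of > 50000 nM in this assay, at which 4 of the 4 values shown sit.

The compounds shown leave open whether any change to the groups on the shared core would give a measurable value in this assay.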